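The source may hold more compounds than are shown below. What is called first, only, known or untested is meant among the compounds shown, and "the series" means these compounds.

Compound 1 `COc1ccc(S(=O)(=O)N2CCc3cccc(-c4ccc(N(C)C)cc4)c32)cc1`: 237 nM
Compound 2 `COc1ccc(S(=O)(=O)N2CCc3cccc(-c4ccncc4)c32)cc1`: 69.5 nM

Both compounds were tested in a functional assay on MKN-45 cells (Homo sapiens) for inhibition, with a stated time of 72 h; a lower number here means a stronger inhibitor, a higher number a weaker inhibitor. Compound 2 holds the lower of the two numbers, which makes it the stronger inhibitor of this pair. Among the compounds with values here, the only measured step is a 3.4-fold lower number from compound 1 to compound 2 (0.53 log units; beyond the scatter), and it came with pyridin-4-yl in place of 4-(dimethylamino)phenyl on an aromatic carbon.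

Compound 3 `COc1ccc(S(=O)(=O)N2CCc3cccc(-c4ccc(O)cc4)c32)cc1` changes that same place, with 4-hydroxyphenyl in place of pyridin-4-yl on an aromatic carbon. The entering group is a six-membered aromatic ring of carbon only, and the group in compound 1 is a substituted phenyl too. Within the data shown here, the one available guide is therefore the modest step of a 3.4-fold lower number from compound 1 to compound 2 (0.53 log units; beyond the scatter), read in reverse. Among the measured compounds shown here, it is a weak guide, since the group on the phenyl differs and no measured compound carries the hydroxy group. For the measured compounds named here, a modest rise in this assay is expected, no larger than that step. The expected change is a 1.9-fold higher number from compound 2 to compound 3 (0.27 log units; within the scatter). For compound 3 the estimated value is 130 nM, with an expected range of 45 nM to 380 nM.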

Compound 3, half-maximal inhibitory concentration: 82.6 nM
The estimate for compound 3 lay 1.6-fold (0.20 log units) above the measured number; the range from low to high includes it.
By their numbers in this assay, from the lowest: compounds 2 and 3 (each within the scatter of the next); then compound 1.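

In this assay, this aromatic carbon takes two different rings with no difference that can be read: 4-hydroxyphenyl in place of pyridin-4-yl gives only a small shift within the scatter (a 1.2-fold higher number from compound 2 to compound 3 (0.07 log units; within the scatter)), so a ring nitrogen is not needed here for a number like that of compound 2. The earlier pair could suggest that a substituted phenyl ring at this place is worse than pyridin-4-yl, but the phenyl ring of compound 3 shows that the ring alone does not set the higher number of compound 1, and hydroxy in place of dimethylamino on that same ring accounts for a modest step beyond the scatter (a 2.9-fold lower number from compound 1 to compound 3 (0.46 log units; beyond the scatter)). No measurement is available here that explains either result.

Going by these compounds, it remains open whether a 4-methoxyphenyl or a 4-aminophenyl group would read like compound 3 or like compound 1, which would show how much the hydrogen on the hydroxy group matters. A plain phenyl ring or a pyridin-3-yl group would also help to show whether the substituent or the place of the ring nitrogen matters more.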